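Methyl on a phenolic oxygen in a cytotoxicity series

This account rests on a few compounds, and the source may have more. Where it says the series, first, only, none or still open, it means among the compounds named here.

In a functional assay on SH-SY5Y cells (Homo sapiens) for cytotoxicity, read by MTT assay, with stated times of 8 h, 30 min and 12 h, tested at 0.05 uM (on this read-out lower numbers stand for a weaker effect and higher numbers for a stronger effect at the one concentration tested), three compounds have been measured. Compound 1 `COc1ccc(CNC(=N)[C@@H]2CCC(=O)N2Cc2ccc(F)cc2)cc1` gives 15.8%, compound 2 `COc1ccc(CN2C(=O)CC[C@H]2C(=N)NCc2ccccc2)cc1` gives 12.3%, and compound 3 `COc1ccc(CN2C(=O)CC[C@H]2C(=N)NCc2ccc(O)cc2)cc1` gives 16%. Compound 3 therefore carries the highest of the three numbers, but it is not separated from either neighbour beyond the scatter: compound 1 lies closest, and the one-place step a number 3.7 percentage points higher from compound 2 to compound 3 (within the scatter) is itself within the scatter.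

Compound 4 `COc1ccc(CNC(=N)[C@@H]2CCC(=O)N2Cc2ccc(OC)cc2)cc1` is the next compound, differing from compound 3 only by methyl in place of hydrogen on an oxygen on an aromatic ring. Among the compounds with values here, no measured step changes this oxygen, so the only guidance is indirect. The single substitution on this ring that has been measured, a number 3.7 percentage points higher from compound 2 to compound 3 (within the scatter), moved the number by an amount inside the scatter, and the whole set spans a band no wider than the scatter. On that basis he expects the step of a number 1 percentage points lower from compound 3 to compound 4 (within the scatter) to stay within the scatter, with no direction favoured. Compound 4 is accordingly estimated at 15%, within a range from 8% to 23%.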

Compound 4, a percentage reported as activity, at one concentration (the size of the read-out at that concentration, not a potency): 24.2%
The estimate for compound 4 lay 9.2 percentage points below the measured number, and the stated range ends below it.
By their numbers in this assay, from the lowest: compounds 2, 1, 3 and 4 (each within the scatter of the next, the first and the last beyond it).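

In this assay methyl in place of hydrogen on the phenolic oxygen gives a number 8.2 percentage points higher from compound 3 to compound 4 (within the scatter) and so does not separate the methoxy compound from the hydroxy compound, while the exchange of fluoro for methoxy gives a number 8.4 percentage points higher from compound 1 to compound 4 (within the scatter) and leaves those two unseparated as well. Only the exchange of hydrogen for methoxy on the aromatic carbon gives a number 11.9 percentage points higher from compound 2 to compound 4 (beyond the scatter) and thus the first modest separation in the series, so at this position methoxy is distinguished from hydrogen but from neither hydroxy nor fluoro. Nothing available explains this result.

Going by these compounds, whether that separation carries over to ethoxy, an amine or a carboxylic acid on the same aromatic carbon remains open. With one concentration per compound, the numbers tell only of a stronger or weaker effect at that concentration.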